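The compounds below may be only part of what the source reports. "The series", "measured", "known", "first", "only" and "open" are said of these compounds alone.

Compound 3 `N#Cc1ccc(O[C@H]2CN(S(=O)(=O)c3ccccc3C#N)C[C@@]2(O)CO)cc1F` gives the lowest of the three numbers measured in an ADME assay on the whole organism (Rattus norvegicus, strain Sprague-Dawley) for pharmacokinetics, read by LC-MS, with a stated time of 30 min (a lower number here means that more of the compound stays in the plasma, a higher number that more of the compound sits outside the plasma), at 0.9 L/kg. Compound 1 `N#Cc1ccc(O[C@H]2CN(S(=O)(=O)c3ccc(Cl)cn3)C[C@@]2(O)CO)cc1F` gives 2.2 L/kg in this assay, and compound 2 `N#Cc1ccc(O[C@H]2CN(S(=O)(=O)c3ccc(Cl)cc3Cl)C[C@@]2(O)CN)cc1F` gives 7.7 L/kg. Compound 4 `N#Cc1ccc(O[C@H]2CN(S(=O)(=O)c3ccc(Cl)cc3Cl)C[C@@]2(O)CO)cc1F` has not yet been measured; it differs from compound 3 in one place: 2,4-dichlorophenyl in place of 2-cyanophenyl on a sulfonyl sulfur. Among the measured compounds shown here, the only measured step at this position, a 2.4-fold lower number from compound 1 to compound 3 (0.39 log units; beyond the scatter), was modest yet beyond the scatter. For the measured compounds named here, compound 2 also carries the 2,4-dichlorophenyl group and gives a higher number than compound 3, though its other change makes no direct step. Compound 4 is therefore expected to move upward from compound 3 by a 2.8-fold higher number from compound 3 to compound 4 (0.44 log units; beyond the scatter). The estimate for compound 4 is 2.5 L/kg, within a range from 1.2 L/kg to 5 L/kg.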

Compound 4, volume of distribution at steady state in the Rattus norvegicus assay: 3.2 L/kg
Beside the measured number, compound 4's estimate is 1.3-fold (0.11 log units) below it, and the stated range covers the measured number.
By their numbers in the Rattus norvegicus assay, from the lowest: compound 3; then compounds 1 and 4 (each within the scatter of the next); then compound 2.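

In the Rattus norvegicus assay a second step at the sulfonyl sulfur (a 3.6-fold higher number from compound 3 to compound 4 (0.55 log units; beyond the scatter)) leaves 2-cyanophenyl with the lowest number of the three groups carrying the hydroxy chain, while 2,4-dichlorophenyl and 5-chloropyridin-2-yl stay level (a 1.5-fold higher number from compound 1 to compound 4 (0.16 log units; within the scatter)). The chain carbon now has its own direct step (a 2.4-fold lower number from compound 2 to compound 4 (0.38 log units; beyond the scatter)), which separates the amino group from the sulfonyl group in compound 2. In a physicochemical assay for solubility, in simulated intestinal fluid, with a stated time of 4 h (a lower number here means a less soluble compound, a higher number a more soluble compound), compound 3 gives 20 ug/mL and compound 4 gives 19 ug/mL, values within the scatter of each other. Still open, going by these compounds, is whether a carboxylic acid or a methyl group in place of 2-cyanophenyl on a sulfonyl sulfur would keep the number as low, and how the amino group reads with 2-cyanophenyl. No evidence at hand accounts for these steps.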